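Compound 3 to compound 4: changing the carbonyl group

The source may hold more compounds than are shown below. What is called first, only, known or untested is meant among the compounds shown, and "the series" means these compounds.

- compound 1 `Cc1ccc2[nH]c(C(=O)N[C@H]3CN(S(=O)(=O)c4ccccc4)C[C@@H]3C(=O)N[C@H]3CCCN(C)C3)cc2c1`: 2.7
- compound 2 `Cc1ccc2[nH]c(C(=O)N[C@H]3CN(S(=O)(=O)c4ccccc4)C[C@@H]3C(=O)N[C@@H]3CCCNC3)cc2c1`: 1.3
- compound 3 `Cc1ccc2[nH]c(C(=O)N[C@H]3CN(S(=O)(=O)c4ccccc4)C[C@@H]3C(=O)N[C@H]3CCCNC3)cc2c1`: 1.3

In a physicochemical assay for lipophilicity, measured as octanol-water partition, at pH 7.4 (on this read-out lower numbers stand for lower lipophilicity and higher numbers for higher lipophilicity), compound 3 gives 1.3, level with compound 2, and together they hold the lowest of the three numbers. The unmeasured compound 4 `Cc1csc(C(=O)N[C@H]2CN(S(=O)(=O)c3ccccc3)C[C@@H]2C(=O)N[C@H]2CCCNC2)n1` differs from compound 3 in one place, on a carbonyl carbon: 4-methyl-1,3-thiazol-2-yl in place of 5-methyl-1H-indol-2-yl on a carbonyl carbon.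

Within the data shown here, no measured step touches that place, so the guidance is indirect. Replacing a methyl with hydrogen on an amine nitrogen in a ring gave a number 1.40 log units lower from compound 1 to compound 3 (beyond the scatter), and the same change in compound 2 gave a number 1.40 log units lower from compound 1 to compound 2 (beyond the scatter). A change of configuration alone gave no change at the digits printed from compound 2 to compound 3 (within the scatter), so it offers no guide to this swap. The one useful hint is that compound 3 arose from a loss of only a methyl in the step of a number 1.40 log units lower from compound 1 to compound 3 (beyond the scatter), while the swap here removes more heavy atoms. The expected step is a number 0.70 log units lower from compound 3 to compound 4 (beyond the scatter), downward and probably beyond the scatter, though smaller or larger steps remain possible at this untested place. For compound 4 the estimated value is 0.6, with an expected range from 0 to 1.2.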

Compound 4, distribution coefficient: 0.1
Estimate against measurement, compound 4: 0.50 log units above, and the stated range covers the measured number.
By their numbers in this assay, from the lowest: compound 4; then compounds 2 and 3 (each within the scatter of the next); then compound 1.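

The group on the carbonyl carbon is a place where this assay responds strongly: the swap to 4-methyl-1,3-thiazol-2-yl gave a number 1.20 log units lower from compound 3 to compound 4 (beyond the scatter). Among these compounds, the earlier steps changed only the piperidin-3-yl group, by a methyl or by configuration, so this is the first sign that the number also depends on the group at this other place. Nothing at hand accounts for the size of this step.

The swap changes several things at once: the two-ring group gives way to a smaller one-ring group, sulfur enters, and the hydrogen-bond donor leaves, and one step cannot separate these changes. As far as these compounds go, it remains open how a thiophene ring on the same carbonyl carbon would compare, and whether restoring the methyl on the ring nitrogen in compound 4 would raise the number as it stands in compound 1.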